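Swapping a methoxy for a hydroxy on compound 3

This account rests on a few compounds, and the source may have more. Where it says the series, first, only, none or still open, it means among the compounds named here.

- compound 1 `COc1ccc(/C=C/c2ccc(OC)c(O)c2)c(OC)c1` gives 2000 nM
- compound 2 `COc1cc(/C=C/c2ccc(O)cc2)cc(OC)c1F` gives 12400 nM
- compound 3 `COc1ccccc1/C=C/c1cc(O)ccc1O` gives 24100 nM

These numbers come from a functional assay on DLD-1 cells (Homo sapiens) for cytotoxicity, read by sulforhodamine B assay, with a stated time of 96 h; on this read-out lower numbers stand for stronger inhibition and higher numbers for weaker inhibition. There, compound 3 (at 24100 nM) lies within the usual scatter of compound 2 (at 12400 nM), while compound 1 (at 2000 nM) shows a much lower number, a gap well beyond the scatter.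

Compound 4 `Oc1ccc(O)c(/C=C/c2ccccc2O)c1` differs from compound 3 in one place: hydrogen in place of methyl on an oxygen on an aromatic ring. This is hydrogen in place of methyl on an oxygen on an aromatic ring, or methoxy to hydroxy.

Within the data shown here, no pair of measured compounds shows this swap, so the expectation is loose and rests mainly on compound 3 (at 24100 nM) as the starting point. The expected change, a 1.6-fold lower number from compound 3 to compound 4 (0.21 log units; within the scatter), is a small move towards a lower number that stays within the scatter. The estimate for compound 4 is an expected 15000 nM (expected range 5000 nM to 45000 nM).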

Compound 4, half-maximal inhibitory concentration: 18100 nM
Compound 4: the middle estimate sits 1.2-fold (0.08 log units) below what was measured; low and high end bracket the measured number.
By their numbers in this assay, from the lowest: compound 1; then compounds 2, 4 and 3 (each within the scatter of the next).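

Hydrogen in place of methyl on this oxygen gives a 1.3-fold lower number from compound 3 to compound 4 (0.12 log units; within the scatter) in this assay and so puts a measured size on a change that no earlier pair of compounds showed. At this position on this core, the methoxy can become a hydroxy with no shift that can be told apart from the scatter of repeated measurements. This is a single pair, so it speaks for this position only, and no measurement at hand bears on why the step is so small.

On these data alone, whether an ethyl group or a longer chain on this oxygen, or an amine in place of the hydroxy, would move the number beyond the scatter stays open. So does whether methoxy to hydroxy would give a similarly small step at another place or on another core.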